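The source may hold more compounds than are shown below. What is called first, only, known or untested is meant among the compounds shown, and "the series" means these compounds.

Compound 1 `CCC(=O)N1CCN(Cc2nc3ccccc3n2Cc2cccc(C)c2)CC1` gives 85.1% in an assay on isolated protein for inhibition of aldehyde dehydrogenase 1A1 (Homo sapiens), read by spectrophotometry, tested at 10 uM; a lower number here means less inhibition, a higher number more inhibition at the concentration tested (going by the name of the read-out). For the measured compounds named here, compound 2 `Cc1cccc(Cn2c(CN3CCN(C(=O)c4ccc(C(C)C)cc4)CC3)nc3ccccc32)c1` gives 67.6% in this assay; the one step measured is a number 17.5 percentage points lower from compound 1 to compound 2 (beyond the scatter), a change confined to the group on the carbonyl carbon. Compound 3 `O=C(C1CC1)N1CCN(Cc2nc3ccccc3n2Cc2cccc(F)c2)CC1` gives 27.2% in this assay and stands lowest of the three numbers: the nearest, compound 2, lies higher by a margin beyond the scatter, and compound 1 lies higher still, again beyond the scatter.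

Compound 4 `O=C(C1CC1)N1CCN(Cc2nc3ccccc3n2Cc2ccccc2)CC1` differs from compound 3 in one place only: hydrogen in place of fluoro on an aromatic carbon. Going by the values given here, no measured step touches this ring; the single known step sits on the carbonyl side and so does not bear on the present change. Nothing in the data therefore points to a shift beyond the scatter, and the expected step is a number 2.8 percentage points higher from compound 3 to compound 4 (within the scatter). Compound 4 is accordingly estimated at 30% in this assay, with a range from 12% to 50%.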

Compound 4, a percentage reported as inhibition, at one concentration (the size of the read-out at that concentration, not a potency): 23.9%
Estimate against measurement, compound 4: 6.1 percentage points above; low and high end bracket the measured number.
By their numbers in this assay, from the lowest: compounds 4 and 3 (each within the scatter of the next); then compound 2; then compound 1.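

In this assay the change from 3-fluorobenzyl to benzyl gives a number 3.3 percentage points lower from compound 3 to compound 4 (within the scatter), the first step read on this ring rather than on the carbonyl side. With the carbonyl side held fixed, fluoro and hydrogen at this place on the six-membered aromatic ring are not told apart by this read-out. No measurement of any other kind bears on this result.

The methyl-bearing benzyl of compound 1 and compound 2 has no partner sharing its carbonyl group among the compounds shown, so methyl cannot yet be set against fluoro or hydrogen at this place. Also open, as far as these compounds go, is how a methoxy, a trifluoromethyl, an amine or a carboxylic acid on this ring would read, and whether the fluoro-to-hydrogen result holds with an ethyl or 4-isopropylphenyl on the carbonyl carbon.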